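This account rests on a few compounds, and the source may have more. Where it says the series, first, only, none or still open, it means among the compounds named here.

Measured in a functional assay on HT-29 cells (Homo sapiens) for antiproliferative activity, read by MTT assay, with a stated time of 48 h; on this read-out higher numbers stand for weaker inhibition of growth and lower numbers for stronger inhibition of growth:
- compound 1 `COC(=O)N1N=C(c2ccccc2)CC1c1cc(OC)c(OC)c(OC)c1`: 6260 nM
- compound 2 `COC(=O)N1N=C(c2cccc(OC)c2)CC1c1cc(OC)c(OC)c(OC)c1`: 1300 nM

Of these two, compound 2 has the lower number, 1300 nM, and its gap to compound 1 lies beyond the scatter. The next compound is compound 3 `COC(=O)N1N=C(c2ccc(OC)cc2)CC1c1cc(OC)c(OC)c(OC)c1`, which keeps the shared core and the methoxycarbonyl group. The change is 4-methoxyphenyl in place of 3-methoxyphenyl on a carbon with a double bond to nitrogen.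

Among the compounds with values here, only one measured step bears on this change: a 4.8-fold lower number from compound 1 to compound 2 (0.68 log units; beyond the scatter), a modest step for methoxy in place of hydrogen on an aromatic carbon. Within the data shown here, no measured compound carries the 4-methoxyphenyl group, so the data do not show how much the position of the methoxy matters. Compound 3 still carries a methoxy, so its number is expected to lie closer to compound 2, at 1300 nM, than to compound 1, at 6260 nM. A small rise in this assay is expected, smaller than the step already measured. The estimated step is a 1.2-fold higher number from compound 2 to compound 3 (0.09 log units; within the scatter). The expected value for compound 3 is 1600 nM, with an estimated range from 500 nM to 5000 nM.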

Compound 3, concentration for 50% growth inhibition: 2550 nM
For compound 3 the middle estimate is 1.6-fold (0.20 log units) below the measured one, and the stated range covers the measured number.
By their numbers in this assay, from the lowest: compounds 2 and 3 (each within the scatter of the next); then compound 1.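

In this assay, setting 4-methoxyphenyl in place of 3-methoxyphenyl on the carbon with a double bond to nitrogen gives a 2.0-fold higher number from compound 2 to compound 3 (0.29 log units; within the scatter), so this read-out does not separate the two methoxyphenyl groups. The comparison with the compound that has no methoxy on this aromatic ring now rests on two compounds rather than one: there is a 2.5-fold lower number from compound 1 to compound 3 (0.39 log units; beyond the scatter), which is beyond the scatter, and among the three compounds shown none goes against a lower number with a methoxy on this ring. No evidence is available that bears on the reason for this result.

The compounds shown leave open whether a hydroxyl group or an amine in place of the methoxy on this aromatic ring would give a number apart from those of compound 2 and compound 3, and whether a second methoxy on the same ring would lower the number further. As far as these compounds go, all three also keep the methoxycarbonyl group, so what an ethoxycarbonyl group or an acetyl group in its place would do in this assay also stays open.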